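The source may report more compounds than this note shows. Statements on the series, on what has been measured and on what is new or still open speak of the compounds shown alone.

Measured compounds:
Compound 1, `CCOC(=O)C1=Cc2ccccc2OC1(OCc1cc(-c2ccc(OC)cc2)no1)C(F)(F)F`: > 150000 nM
Compound 2, `O=C(O)C1=Cc2ccccc2OC1(OCc1cc(-c2cccc(C(F)(F)F)c2)no1)C(F)(F)F`: > 150000 nM

In a functional assay on MCF7 cells (Homo sapiens) for inhibition, read by MTT assay, with a stated time of 24 h (on this read-out higher numbers stand for weaker inhibition and lower numbers for stronger inhibition), neither compound gave a number. For compound 2 the result is a limit of the assay, > 150000 nM, meaning that no inhibition strong enough to be measured was seen within the tested range. Compound 1 sits at the same limit, > 150000 nM, so both values shown are limits, as summarised in the limit of > 150000 nM in this assay, at which 2 of the 2 values shown sit. Nothing therefore places compound 2 above or below any other compound; it simply stands at the edge of what this assay can report.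

Compound 3, `COc1ccc(-c2cc(COC3(C(F)(F)F)Oc4ccccc4C=C3C(=O)O)on2)cc1`, differs from compound 2 in one place: 4-methoxyphenyl in place of 3-(trifluoromethyl)phenyl on an aromatic carbon. Going by the values given here, since no step between two measured compounds is available, the size of this change cannot be read from the numbers; what is known is that the 4-methoxyphenyl group also appears in compound 1, which likewise reached only the limit. The expected step that the limit leaves unreadable from compound 2 to compound 3 is therefore none beyond the usual scatter. Compound 3 is expected to give 200000 nM, with a range from 100000 nM to 500000 nM, most likely again reported only as a limit.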

Compound 3, half-maximal inhibitory concentration: 35200 nM
Estimate against measurement, compound 3: 5.7-fold (0.75 log units) above; the whole stated range lies above it.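

In this assay, 4-methoxyphenyl in place of 3-(trifluoromethyl)phenyl, on the aromatic carbon next to the ring nitrogen, gives an at least 4.2-fold lower number from compound 2 to compound 3 (0.62 log units; beyond the scatter) and so turns an unreadable result into a real number. With the 4-methoxyphenyl group kept, hydrogen in place of ethyl on the oxygen next to a carbonyl group gives an at least 4.2-fold lower number from compound 1 to compound 3 (0.62 log units; beyond the scatter); among these three compounds, therefore, a number appears only when the 4-methoxyphenyl group and the carboxylic acid occur together. Both steps give only the smallest possible size of the change, because their starting compounds stand at a limit rather than at a measured value: the limit of > 150000 nM in this assay, at which 2 of the 3 values shown sit.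

The compounds shown leave open how large either step really is, and whether the gain at this position comes from the methoxy group itself or from the loss of trifluoromethyl, since one swap changes both the group and its place on the phenyl ring. They also leave open whether a plain phenyl ring at this position, or an amide in place of the carboxylic acid, would still give a readable number.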